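The source may hold more compounds than are shown below. What is called first, only, known or untested is meant among the compounds shown, and "the series" means these compounds.

Measured compounds:
compound 1 `CC(C)(N)CC(=O)N[C@@H]1CCc2ccccc2N(Cc2ccc(-c3ccccc3C(N)=O)cc2)C1=O` with 0.08 uM
compound 2 `CC(O)Cn1nnc(-c2ccccc2-c2ccc(CN3C(=O)[C@H](NC(=O)CC(C)(C)N)CCc4ccccc43)cc2)n1` with 0.05 uM
compound 3 `CC(C)(N)CC(=O)N[C@@H]1CCc2ccccc2N(Cc2ccc(-c3ccccc3C(=O)O)cc2)C1=O` with 3 uM

In a functional assay (Pituitary gland cell) with Rattus norvegicus as the target (on this read-out higher numbers stand for an effect only at larger amounts of compound and lower numbers for an effect already at smaller amounts), compound 2 gives the lowest of the three numbers; its nearest neighbour is compound 1, separated by a 1.6-fold lower number from compound 1 to compound 2 (0.20 log units; within the scatter), and its furthest is compound 3, separated by a 60-fold higher number from compound 2 to compound 3 (1.78 log units; beyond the scatter). Compound 4 `CC(C)(N)CC(=O)N[C@@H]1CCc2ccccc2N(Cc2ccc(-c3ccccc3C#N)cc2)C1=O` has not yet been measured. It differs from compound 2 in one place: cyano in place of 2-(2-hydroxypropyl)-2H-tetrazol-5-yl on an aromatic carbon.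

Among the measured compounds shown here, no measured step exchanges this group for a cyano. The two steps that bear on the same position are a 1.6-fold lower number from compound 1 to compound 2 (0.20 log units; within the scatter), which was small, and a 60-fold higher number from compound 2 to compound 3 (1.78 log units; beyond the scatter), which was large. The cyano group is neutral and carries one hydrogen-bond acceptor, like the carbamoyl of compound 1 rather than the carboxy of compound 3, so compound 4 is expected to land near compound 1, with a step of a 3.0-fold higher number from compound 2 to compound 4 (0.48 log units; beyond the scatter) expected from compound 2. The estimate for compound 4 in this assay is 0.15 uM, between 0.04 uM and 0.6 uM.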

Compound 4, concentration for half-maximal effect: 5 uM
The estimate for compound 4 lay 33-fold (1.52 log units) below the measured number; the measured number lies above the stated range.
By their numbers in this assay, from the lowest: compounds 2 and 1 (each within the scatter of the next); then compounds 3 and 4 (each within the scatter of the next).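

In this assay, the step of a 63-fold higher number from compound 1 to compound 4 (1.80 log units; beyond the scatter) shows that, on this aromatic carbon, nitrile does not stand in for carbamoyl, and the step of a 100-fold higher number from compound 2 to compound 4 (2.00 log units; beyond the scatter) shows that it does not stand in for 2-(2-hydroxypropyl)-2H-tetrazol-5-yl either. The step of a 1.7-fold higher number from compound 3 to compound 4 (0.22 log units; within the scatter) instead places nitrile with carboxy, so the position now divides these four groups into two pairs. The large loss seen earlier with carboxy is therefore not unique to that group. No available evidence explains this division. As far as these compounds go, it remains open whether an aminomethyl group or a tetrazole without the hydroxypropyl chain would fall with carbamoyl or with nitrile.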